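This account rests on a few compounds, and the source may have more. Where it says the series, first, only, none or still open, it means among the compounds named here.

Measured compounds in a functional assay on MDA-MB-435 cells (Homo sapiens) for inhibition, read by sulforhodamine B assay, with a stated time of 48 h; on this read-out higher numbers stand for weaker inhibition of growth and lower numbers for stronger inhibition of growth:
- compound 2, `N=C(N)c1ccc(-c2ccc(-c3ccc(F)cc3)o2)o1`: 350 nM
- compound 1, `N=C(N)c1ccc(-c2ccc(-c3cncc4ccccc34)s2)s1`: 2030 nM

Compound 2 stands at the lower of the two numbers in this assay; compound 1 gives the higher number, and the gap between the two lies beyond the usual scatter of repeated measurements. The two compounds differ in more than one place, so their gap cannot be tied to a single change.

Compound 3 is `N=C(N)c1ccc(-c2ccc(-c3ccc(Cl)cc3)o2)o1`. It differs from compound 2 by chloro in place of fluoro on an aromatic carbon. Within the data shown here, no pair of measured compounds shows this change, so its size cannot be read from the set. In this assay the step is expected to be small, either none beyond the scatter or a slight move toward a lower number. Compound 3 is expected to give 280 nM, with a range from 110 nM to 750 nM. The expected step is a 1.3-fold lower number from compound 2 to compound 3 (0.10 log units; within the scatter), within the scatter.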

Compound 3, concentration for 50% growth inhibition: 1380 nM
For compound 3 the middle estimate is 4.9-fold (0.69 log units) below the measured one; measured number outside the range, above it.
By their numbers in this assay, from the lowest: compound 2; then compounds 3 and 1 (each within the scatter of the next).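

In this assay, among these compounds, the place on an aromatic carbon para to a large group proves sensitive to the identity of the halogen: chloro in place of fluoro gives a 3.9-fold higher number from compound 2 to compound 3 (0.60 log units; beyond the scatter) as the first step that can be tied to a single change. One heavy atom exchanged for one heavy atom, with no change in ring count, hydrogen-bond donors, hydrogen-bond acceptors or net charge, is enough to move the number beyond the scatter. Nothing measured on these compounds accounts for the size or direction of this step.

Among the compounds shown here, with only this one pair, it remains open whether the trend continues with bromo, or how a methoxy or an amine would behave at the same place. Whether the step carries over to the core of compound 1 also cannot be read from the compounds shown.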